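Pyridin-3-yl in place of quinolin-3-yl in compound 3

A few compounds are considered here, and "the series" means these few. Any claim that something is new, unique, unknown or untested is made for them only; others in the source may bear on it.

Results so far in a functional assay on VCaP cells (Homo sapiens) for antiproliferative activity, read by CCK-8 assay, with a stated time of 6 days (on this read-out lower numbers stand for stronger inhibition and higher numbers for weaker inhibition), are as follows.

compound 1 `N#Cc1ccc(N2CCc3cc(-c4cnc5ccccc5c4)ccc32)cc1C(F)(F)F`: "not determined" (no result reported)
compound 2 `CCN(c1ccc(C#N)c(Cl)c1)c1cc(-n2cccn2)ccc1C`: 2340 nM
compound 3 `N#Cc1ccc(N2CCc3cc(-c4cnc5ccccc5c4)ccc3C2)cc1C(F)(F)F`: > 30000 nM

For compound 3 the entry > 30000 nM is a limit and not a number. That is the limit of > 30000 nM in this assay, at which 1 of the 3 values shown sits, so compound 3 has no exact place on the scale. For the measured compounds named here, compound 2, at 2340 nM, carries the only single number in the set, and it does not share the core of compound 3.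

Compound 4 `N#Cc1ccc(N2CCc3cc(-c4cccnc4)ccc3C2)cc1C(F)(F)F` has not yet been measured. It differs from compound 3 at one place, (pyridin-3-yl in place of quinolin-3-yl on an aromatic carbon), with pyridin-3-yl in place of quinolin-3-yl on an aromatic carbon. Going by the values given here, no measured pair shows what such a swap does in this assay, so the expectation rests on compound 3 alone. Its limit of > 30000 nM is the only anchor for that expectation. The estimated step of an at least 1.2-fold lower number from compound 3 to compound 4 (0.07 log units; that floor lies within the scatter) is expected to be small, with perhaps nothing beyond the scatter and no clear gain in inhibition. Compound 4 is expected at about 25000 nM, with an estimated range from 8000 nM to 45000 nM, and it may well be reported only as a limit.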

Compound 4, half-maximal inhibitory concentration: 2530 nM
Compound 4: the middle estimate sits 9.9-fold (0.99 log units) above what was measured; the measured number lies below the stated range.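

In this assay, for the compounds shown here, pyridin-3-yl in place of quinolin-3-yl on the aromatic carbon gives an at least 11-fold lower number from compound 3 to compound 4 (1.07 log units; beyond the scatter), the first reading of how this position responds to a change of group, and the response is large. Both groups hold a six-membered aromatic ring with 1 hetero atom and 1 hydrogen-bond acceptor, so the step coincides with the loss of the six-membered aromatic ring of carbon only and not with a change in the acceptor count. Compound 3 stands only as a limit, > 30000 nM, and not as a number, so the true size of the step stays unknown and only its lower bound is given: the limit of > 30000 nM in this assay, at which 1 of the 4 values shown sits.

The compounds shown leave open whether the ring nitrogen of pyridin-3-yl matters at this carbon or whether the smaller ring alone goes with the lower number, a question that a plain phenyl ring or a pyridin-4-yl group at the same place would address. They also do not show whether a polar substituent on the pyridine ring, such as an amine or a carboxylic acid, would lower the number further.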